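The source may report more compounds than this note shows. Statements on the series, on what has been measured and on what is new or still open speak of the compounds shown alone.

Working notes on the series. In a functional assay on DU-145 cells (Homo sapiens) for inhibition, read by trypan blue exclusion, with a stated time of 72 h (on this read-out lower numbers stand for stronger inhibition and higher numbers for weaker inhibition), compound 1 `Cn1c(=O)c(S(=O)(=O)c2ccc(F)cc2F)cc2cnc(Nc3ccc4cc[nH]c4c3)nc21` gives 5000 nM. Compound 2 `Cn1c(=O)c(S(=O)(=O)c2ccc(F)cc2)cc2cnc(Nc3ccc4occc4c3)nc21` gives 5000 nM in this assay. Compound 3 `Cn1c(=O)c(S(=O)(=O)c2ccc(F)cc2F)cc2cnc(Nc3ccc4occc4c3)nc21` gives 15000 nM in this assay, the highest of the three numbers; the two steps leading into it are a 3.0-fold higher number from compound 1 to compound 3 (0.48 log units; beyond the scatter) and a 3.0-fold higher number from compound 2 to compound 3 (0.48 log units; beyond the scatter).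

Compound 4 `Cn1c(=O)c(S(=O)(=O)c2ccc(F)cc2F)cc2cnc(Nc3ccc4[nH]ncc4c3)nc21` differs from compound 3 only at the bicyclic group on the ring nitrogen: 1H-indazol-5-yl in place of 1-benzofuran-5-yl on a nitrogen on an aromatic ring. For the measured compounds named here, of the measured steps, only the one from compound 1 to compound 3 bears on this change, as it also swaps the bicyclic group on that nitrogen while the sulfonyl ring is the same in compound 1, compound 3 and compound 4. There, exchanging 1H-indol-6-yl for 1-benzofuran-5-yl raised the number. The entering 1H-indazol-5-yl resembles the 1H-indol-6-yl of compound 1 more than the 1-benzofuran-5-yl it replaces, so a step of comparable size in the lowering direction is expected, though the indazole is not the indole and the direction cannot be taken as certain. Compound 4 is therefore expected to give about 5000 nM in this assay, within 2000 nM to 15000 nM, an expected step of a 3.0-fold lower number from compound 3 to compound 4 (0.48 log units; beyond the scatter).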

Compound 4, half-maximal inhibitory concentration: 30000 nM
Beside the measured number, compound 4's estimate is 6.0-fold (0.78 log units) below it; measured number above the stated range.
By their numbers in this assay, from the lowest: compounds 1 and 2 (each within the scatter of the next); then compounds 3 and 4 (each within the scatter of the next).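

In this assay, the change from 1-benzofuran-5-yl to 1H-indazol-5-yl on this nitrogen gives a 2.0-fold higher number from compound 3 to compound 4 (0.30 log units; within the scatter), so the two bicyclic groups are not told apart here, although the entering group has a hydrogen-bond donor and the leaving group has none. The 1H-indazol-5-yl group does not reproduce the 1H-indol-6-yl group at this place, the step being a 6.0-fold higher number from compound 1 to compound 4 (0.78 log units; beyond the scatter), so compound 1 stands apart from both compound 3 and compound 4 among the compounds sharing this sulfonyl ring. Nothing at hand accounts for these differences.

The step from compound 1 to compound 4 changes both the ring and the point of attachment, and 1H-indol-5-yl or 1H-indazol-6-yl would separate the two. Also open, from the compounds shown here alone, is how a single phenyl ring carrying a piperazine or a carboxylic acid would read on this nitrogen.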